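Trimming the Hydroxy Side Chain at the Quinone Amine

The compounds below may be only part of what the source reports. "The series", "measured", "known", "first", "only" and "open" are said of these compounds alone.

Compound 1, `CC1=CCC[C@](C)(CC/C(C)=C/CC2=C(O)C(=O)C=C(N[C@H](C(=O)O)[C@H](C)O)C2=O)[C@@H]1C`, in an ADME assay on L1210 cells (Mus musculus) for cytotoxicity, with a stated time of 48 h (on this read-out lower numbers stand for stronger inhibition and higher numbers for weaker inhibition), gives > 10 ug/mL, which is a limit of the assay rather than a number.
Compound 2, `CC1=CCC[C@](C)(CC/C(C)=C/CC2=C(O)C(=O)C=C(N[C@H](C(=O)O)C(C)C)C2=O)[C@@H]1C`, gives 3.4 ug/mL.
Compound 3, `CC1=CCC[C@](C)(CC/C(C)=C/CC2=C(O)C(=O)C=C(N[C@@H](C(=O)O)[C@H](C)O)C2=O)[C@@H]1C`, gives > 10 ug/mL, again only a limit.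

Compound 3 therefore stands at the limit together with compound 1, and only compound 2 has a readable number (the limit of > 10 ug/mL in this assay, at which 2 of the 3 values shown sit). Compound 4, `CC1=CCC[C@](C)(CC/C(C)=C/CC2=C(O)C(=O)C=C(N[C@H](CO)C(=O)O)C2=O)[C@@H]1C`, differs from compound 3 by hydrogen in place of methyl on a saturated chain carbon bound to an oxygen on a saturated carbon and a saturated chain carbon. Among the measured compounds shown here, two measured steps bear on this change. The step of an at least 2.9-fold higher number from compound 2 to compound 3 (0.46 log units; beyond the scatter) shows that replacing the isopropyl by the hydroxy-bearing side chain pushes the number out to the limit. The step that the two limits leave unreadable from compound 1 to compound 3 cannot be read, as both values are limits (the limit of > 10 ug/mL in this assay, at which 2 of the 3 values shown sit). For the measured compounds named here, the change to compound 4 keeps the hydroxy group and removes only a methyl, and no measured step tests that removal on its own. The expected step that the limit leaves unreadable from compound 3 to compound 4 is therefore one that stays within the scatter, with compound 4 most likely reported as a limit as well. Compound 4 is estimated at 15 ug/mL, within 5 ug/mL and 40 ug/mL.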

Compound 4, half-maximal inhibitory concentration: > 10 ug/mL
Compound 4 was reported as a limit; the forecaster's own chance of this, stated with the estimate: 70%; the middle value is on the limit's open side.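

Shortening 1-hydroxyethyl to hydroxymethyl does not bring a readable number in this assay: compound 4 gives > 10 ug/mL, which is a limit of the assay and not a number. Measured against compound 2, the change to this shorter hydroxy-bearing side chain gives an at least 2.9-fold higher number from compound 2 to compound 4 (0.46 log units; beyond the scatter), so compound 4 joins compound 1 and compound 3 in standing apart from the isopropyl compound. The steps from compound 1 and from compound 3 to compound 4 cannot be read, as only limits stand at both ends: the limit of > 10 ug/mL in this assay, at which 3 of the 4 values shown sit.

What the methyl contributes on its own stays open: none of the hydroxy-bearing compounds shown has a readable number. As far as these compounds go, it is also open whether an amine in place of the hydroxy group, or a longer chain carrying it, would give a readable number in this assay.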